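This account rests on a few compounds, and the source may have more. Where it says the series, first, only, none or still open, it means among the compounds named here.

Measured so far in a functional assay on HT-29 cells (Homo sapiens) for cytotoxicity, read by MTT assay, with a stated time of 72 h; a higher number here means a weaker inhibitor, a lower number a stronger inhibitor:
- Compound 1, `COc1cc2c(Oc3ccc(NC(=O)c4nn(-c5ccccc5F)c(=O)c5ccccc45)cc3F)ccnc2cc1OCCCN1CCN(C)CC1`: 480 nM
- Compound 2, `COc1cc2c(Oc3ccc(NC(=O)c4nn(-c5ccccc5)c(=O)c5ccccc45)cc3F)ccnc2cc1OCCCN1CCC(C)CC1`: 1040 nM
- Compound 3, `COc1cc2c(Oc3ccc(NC(=O)c4nn(-c5ccc(F)cc5)c(=O)c5ccccc45)cc3F)ccnc2cc1OCCCN1CCC(C)CC1`: 330 nM

Compound 3 gives the lowest of the three numbers. Its nearest neighbour is compound 1, whose value sits within the scatter of it, so no order between these two can be read; compound 2 lies further away, beyond the scatter.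

The next compound, compound 4, `COc1cc2c(Oc3ccc(NC(=O)c4nn(-c5ccccc5F)c(=O)c5ccccc45)cc3F)ccnc2cc1OCCCN1CCC(C)CC1`, keeps everything in compound 3 but one piece: 2-fluorophenyl in place of 4-fluorophenyl on an aromatic nitrogen. The fluorine thus stays on the phenyl ring but moves from one position to another.

Among the compounds with values here, one measured step bears on this ring. There was a 3.2-fold lower number from compound 2 to compound 3 (0.50 log units; beyond the scatter), which shows that a fluorine on this ring matters to this assay. Within the data shown here, no measured step compares the two fluorine positions directly. Compound 1, which carries the 2-fluorophenyl, and compound 3, which carries the 4-fluorophenyl, differ in the amine as well, and their values lie within the scatter of each other. Taken together, the fluorine appears to be worth keeping, and its position seems to make little difference. Compound 4 is therefore expected to remain close to compound 3, with a 1.3-fold higher number from compound 3 to compound 4 (0.10 log units; within the scatter) expected to fall within the scatter, giving an estimate of 420 nM with a range from 180 nM to 1000 nM.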

Compound 4, half-maximal inhibitory concentration: 510 nM
Compound 4: the middle estimate sits 1.2-fold (0.08 log units) below what was measured; measured number inside the range.
By their numbers in this assay, from the lowest: compounds 3, 1 and 4 (each within the scatter of the next); then compound 2.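

In this assay, within the data shown here, the first direct comparison of the two fluorine positions on this ring gives a 1.5-fold higher number from compound 3 to compound 4 (0.19 log units; within the scatter), so 2-fluorophenyl and 4-fluorophenyl on the aromatic nitrogen cannot be put in any order. Until now, only the 4-fluorophenyl had been set against the unsubstituted phenyl, and the new pair gives a 2.0-fold lower number from compound 2 to compound 4 (0.31 log units; beyond the scatter), a modest step that shows the 2-fluorophenyl also stands apart from phenyl in this series. Among these compounds, compound 4 also supplies the first comparison that isolates the amine, with a 1.1-fold higher number from compound 1 to compound 4 (0.03 log units; within the scatter), so with 2-fluorophenyl on the ring nitrogen, 4-methylpiperidin-1-yl and 4-methylpiperazin-1-yl cannot be told apart.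

No supporting measurement is available to explain any of these three steps. Going by these compounds, it remains open whether a chlorine or a methoxy group in place of the fluorine would give a similar number, and whether a morpholine on the same chain would fall with the two amines compared here.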